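A few compounds are considered here, and "the series" means these few. Any claim that something is new, unique, unknown or untested is made for them only; others in the source may bear on it.

Measured so far in this series:
compound 1, `CC[C@H](C)[C@H](NCc1ccc(C(=N)N)cc1)C(=O)[C@@H](CCCNC(=N)N)NS(=O)(=O)Cc1ccccc1`: 23 nM
compound 2, `N=C(N)NCCC[C@@H](NS(=O)(=O)Cc1ccccc1)C(=O)[C@H](CC(=O)O)NCc1ccc(C(=N)N)cc1`: 422 nM

Among the compounds with values here, in an assay on isolated protein for inhibition of transmembrane protease serine 11D (Homo sapiens), read by fluorescence (a lower number here means a stronger inhibitor, a higher number a weaker inhibitor), compound 2 gives the higher of the two numbers, with compound 1 as its only neighbour. Within the data shown here, the single measured step, an 18-fold higher number from compound 1 to compound 2 (1.26 log units; beyond the scatter), is large and well beyond the scatter; it brought carboxymethyl in for sec-butyl on the carbon bound to the amine nitrogen and the carbonyl carbon.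

Compound 3, `N=C(N)NCCC[C@H](NCc1ccc(C(=N)N)cc1)C(=O)[C@@H](CCCNC(=N)N)NS(=O)(=O)Cc1ccccc1`, is not yet measured. Against compound 2 it carries a group of 6 heavy atoms (3 carbon, 3 nitrogen; no ring) in place of a group of 3 heavy atoms (1 carbon, 2 oxygen; no ring), on a saturated chain carbon, two bonds along the chain from an amine nitrogen and a carbonyl carbon. Among the measured compounds shown here, the only step that bears on this is the one from compound 1 to compound 2, since it concerns the same carbon and was large. Compound 3 removes the carboxy group that step introduced and puts in its place a chain of the kind already present in the shared core. The expected move in this assay is therefore back toward the number of compound 1, estimated as a 28-fold lower number from compound 2 to compound 3 (1.45 log units; beyond the scatter). For compound 3 the estimate is 15 nM, with a range of 4 nM to 60 nM.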

Compound 3, inhibition constant: 457 nM
Beside the measured number, compound 3's estimate is 30-fold (1.48 log units) below it; the whole stated range lies below it.
By their numbers in this assay, from the lowest: compound 1; then compounds 2 and 3 (each within the scatter of the next).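

In this assay, the carboxy group and the group of 6 heavy atoms in its place are not told apart on this carbon: a 1.1-fold higher number from compound 2 to compound 3 (0.03 log units; within the scatter) stays within the scatter. The second side chain also falls well short of sec-butyl, with a 20-fold higher number from compound 1 to compound 3 (1.30 log units; beyond the scatter) on the saturated chain carbon bound to an amine nitrogen and a carbonyl carbon, so the shortfall of compound 2 is not particular to carboxymethyl. With three compounds, sec-butyl alone holds the lowest number here, and no supporting data bear on the reason for this.

Still open, going by these compounds, is whether other hydrocarbon groups, such as isopropyl, isobutyl or cyclohexyl, match sec-butyl on this carbon. Also open, on these data alone, is whether a primary amine on a butyl chain, or a hydroxymethyl group, reads like compound 3 or like compound 1.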